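The source may hold more compounds than are shown below. What is called first, only, known or untested is meant among the compounds shown, and "the series" means these compounds.

In a functional assay on HCT-116 cells (Homo sapiens) for inhibition, read by sulforhodamine B assay, with a stated time of 48 h (a higher number here means a weaker inhibitor of growth, a lower number a stronger inhibitor of growth), compound 1 `O=C(Cc1csc2nc(-c3ccc(Br)cc3)cn12)N/N=C/c1ccccc1O` gives 12300 nM and compound 2 `COc1cccc(OC)c1/C=N/NC(=O)Cc1csc2nc(-c3ccc(Br)cc3)cn12` gives 15800 nM and so stands level with compound 1 within the scatter. Compound 3 `O=C(Cc1csc2nc(-c3ccc(Br)cc3)cn12)N/N=C/c1ccc(Cl)cc1Cl` has 2,4-dichlorophenyl in place of 2,6-dimethoxyphenyl on a carbon with a double bond to nitrogen. Among the measured compounds shown here, the one measured step at this place is a 1.3-fold higher number from compound 1 to compound 2 (0.11 log units; within the scatter) and no measured compound carries 2,4-dichlorophenyl, so no step beyond the scatter is expected in this assay in either direction. The expected step is a 1.2-fold lower number from compound 2 to compound 3 (0.07 log units; within the scatter) and stays within the scatter. Compound 3 is estimated at 13500 nM with 6000 nM to 30000 nM as its expected range.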

Compound 3, concentration for total growth inhibition: 37200 nM
Compound 3: middle estimate off by 2.8-fold (0.44 log units), on the low side; the whole stated range lies below it.
By their numbers in this assay, from the lowest: compounds 1 and 2 (each within the scatter of the next); then compound 3.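

In this assay, the group on a carbon with a double bond to nitrogen can shift the number beyond the scatter: 2,4-dichlorophenyl gives a 2.4-fold higher number from compound 2 to compound 3 (0.37 log units; beyond the scatter) and a 3.0-fold higher number from compound 1 to compound 3 (0.48 log units; beyond the scatter). Compound 3 is therefore a weaker inhibitor of growth than both other compounds, whereas 2-hydroxyphenyl and 2,6-dimethoxyphenyl stand level within the scatter. Nothing available bears on the reason for these steps. On these data alone, it remains open whether the higher number belongs to the chlorine atoms themselves, and whether an amine or a carboxylic acid on this aromatic ring would bring the number down.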